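Compound 3 to compound 4: aryl change

The source may report more compounds than this note shows. Statements on the series, on what has been measured and on what is new or still open speak of the compounds shown alone.

In a functional assay on B16-F10 cells (Mus musculus) for antiproliferative activity, read by MTT assay, with a stated time of 48 h (a lower number here means a stronger inhibitor, a higher number a weaker inhibitor), compound 3 `COc1ccc(/C=C/c2cc(OC)cc(OC)c2/C=C/C(=O)c2ccc(Cl)cc2)cc1` gives 4.9 ug/mL as its reading, alongside compound 2 `COc1ccc(/C=C/c2cc(OC)cc(OC)c2/C=C/C(=O)c2ccc(F)cc2)cc1` at 5.3 ug/mL and compound 1 `COc1ccc(/C=C/c2cc(OC)cc(OC)c2/C=C/C(=O)c2ccc(Cl)c(Cl)c2)cc1` at 7.5 ug/mL in the same test. On these numbers, compound 3 cannot be separated from either of the other two.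

Compound 4 `COc1ccc(/C=C/c2cc(OC)cc(OC)c2/C=C/C(=O)c2ccc(C)cc2C)cc1` differs from compound 3 by 2,4-dimethylphenyl in place of 4-chlorophenyl on a carbonyl carbon with 2,4-dimethylphenyl in place of 4-chlorophenyl on a carbonyl carbon. Within the data shown here, the measured changes at this group are the only guide: a 1.4-fold lower number from compound 1 to compound 2 (0.15 log units; within the scatter) together with a 1.5-fold lower number from compound 1 to compound 3 (0.18 log units; within the scatter) and a 1.1-fold lower number from compound 2 to compound 3 (0.03 log units; within the scatter) all stay within the scatter. Among the measured compounds shown here, no measured compound carries a methyl group there, so the range is kept wide. With those steps as the basis, no step beyond the scatter is expected in this assay for this change. The expected step is a 1.1-fold higher number from compound 3 to compound 4 (0.05 log units; within the scatter) as an estimate. For compound 4 the estimated value is 5.5 ug/mL with an expected range from 2.5 ug/mL to 12 ug/mL in this test.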

Compound 4, half-maximal inhibitory concentration: 4 ug/mL
Compound 4: middle estimate off by 1.4-fold (0.14 log units), on the high side; measured number inside the range.
By their numbers in this assay, from the lowest: compounds 4, 3, 2 and 1 (each within the scatter of the next).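

Across the aryl groups on this carbonyl carbon, 2,4-dimethylphenyl, the only one shown without halogen, stays within the scatter of all three halogenated comparators in this assay (a 1.2-fold lower number from compound 3 to compound 4 (0.09 log units; within the scatter); a 1.3-fold lower number from compound 2 to compound 4 (0.12 log units; within the scatter); a 1.9-fold lower number from compound 1 to compound 4 (0.27 log units; within the scatter)). A halogen on this aryl ring is therefore not required for a reading in this range, and a methyl-bearing ring is tolerated here as well as the 4-chlorophenyl, 4-fluorophenyl and 3,4-dichlorophenyl groups. Nothing measured accounts for how closely these readings sit together.

The two methyl groups of compound 4 are shown only together, so 4-methylphenyl would be needed to separate their contributions. From the compounds shown here alone, whether an aryl group bearing an amine or a carboxylic acid, or a pyridine ring in place of the aryl group, would give a step beyond the scatter remains open.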